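Series notes: urea to benzamide on the compound 2 scaffold

The source may report more compounds than this note shows. Statements on the series, on what has been measured and on what is new or still open speak of the compounds shown alone.

Of the compounds shown here, two have been measured so far. In a functional assay on SK-OV-3 cells (Homo sapiens) for inhibition, read by sulforhodamine B assay, with a stated time of 48 h, tested at 10 uM (on this read-out lower numbers stand for a stronger effect and higher numbers for a weaker effect at the one concentration tested), compound 1 `O=C(Nc1cccc(-n2cc(-c3ccncc3)c(-c3cc(O)cc(Cl)c3)n2)c1)Nc1ccc(Cl)c(C(F)(F)F)c1` gives 63.1%. Compound 2 `COc1cc(Cl)cc(-c2nn(-c3cccc(NC(=O)Nc4ccc(Cl)c(C(F)(F)F)c4)c3)cc2-c2ccncc2)c1` differs by a number 51.1 percentage points lower from compound 1 to compound 2 (beyond the scatter), and in this assay compound 2 gives 12%, the lowest of the two numbers; its nearest neighbour is compound 1.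

Compound 3 `COc1cc(Cl)cc(-c2nn(-c3cccc(NC(=O)c4cccc(C(F)(F)F)c4)c3)cc2-c2ccncc2)c1` is not yet measured. It differs from compound 2 by 3-(trifluoromethyl)phenyl in place of (4-chloro-3-(trifluoromethyl)phenyl)amino on a carbonyl carbon. Within the data shown here, no measured step bears on this change: the only step recorded, from compound 1 to compound 2, concerns the methyl on the oxygen and not the carbonyl end, so its size gives no guidance here. Among the measured compounds shown here, with no comparable step, a weaker effect than compound 2 is expected but with wide uncertainty, the step being estimated as a number 33 percentage points higher from compound 2 to compound 3 (beyond the scatter). For compound 3 in this assay the estimate is 45%, within 15% to 80%.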

Compound 3, a percentage reported as activity, at one concentration (the size of the read-out at that concentration, not a potency): 81.6%
Estimate against measurement, compound 3: 36.6 percentage points below; the measured number lies above the stated range.
By their numbers in this assay, from the lowest: compound 2; then compound 1; then compound 3.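

In this assay, 3-(trifluoromethyl)phenyl in place of (4-chloro-3-(trifluoromethyl)phenyl)amino on the carbonyl carbon gives a number 69.6 percentage points higher from compound 2 to compound 3 (beyond the scatter), so the effect at the one concentration tested depends strongly on this end of the molecule as well as on the methyl on the oxygen. Among these compounds, the single step removes the amino nitrogen, with its hydrogen-bond donor, and the chlorine together, so the contribution of each cannot be separated. No available evidence bears on the reason for the size of this step.

The compounds shown leave open whether the weaker effect follows the loss of the amino nitrogen or the loss of the chlorine. A carbonyl carbon carrying 3-(trifluoromethyl)phenylamino, or one carrying 4-chloro-3-(trifluoromethyl)phenyl, would divide the step into those two parts.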